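A few compounds are considered here, and "the series" means these few. Any claim that something is new, unique, unknown or untested is made for them only; others in the source may bear on it.

In an in vitro ADME assay on microsomes (Rattus norvegicus) for metabolic stability (on this read-out lower numbers stand for a shorter-lived compound and higher numbers for a longer-lived compound), compound 1 (`CCc1nc(-c2ccc(OC(F)(F)F)cc2OC)c(CC)nc1NC(CC)CC`) gives 0.0417 h and compound 2 (`CCc1nc(-c2ccc(Cl)cc2Cl)c(CC)nc1NC(COC)COC`) gives 0.0417 h while compound 3 (`CCC(CC)Nc1nc(C)c(-c2ccc(Cl)cc2Cl)nc1C`) gives 0.0533 h on the same read-out. Compound 2 thus stands level with compound 1, and all three values lie within the usual scatter of repeat measurements. Compound 4 (`CCc1nc(-c2ccc(Cl)cc2Cl)c(CC)nc1CC(CC)CC`) has 2-ethylbutyl in place of (2-methoxy-1-(methoxymethyl)ethyl)amino on an aromatic carbon. Among the measured compounds shown here, no measured pair differs in just one place, so the only guide is that compound 3 at 0.0533 h stays within the scatter of compound 2 at 0.0417 h despite their differing structures. No step beyond the scatter is therefore expected in this assay for this change. The estimated shift is small (a 1.2-fold higher number from compound 2 to compound 4 (0.08 log units; within the scatter)). Compound 4 is expected to show a half-life of 0.05 h (estimated range 0.03 h to 0.1 h).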

Compound 4, half-life: 0.0417 h
For compound 4 the middle estimate is 1.2-fold (0.08 log units) above the measured one; the measured number falls inside the stated range.
By their numbers in this assay, from the lowest: compounds 1, 2, 4 and 3 (each within the scatter of the next).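

In this assay, the change at this position gives no change at the digits printed from compound 2 to compound 4 (within the scatter). Among the compounds shown here, this is the first step that can be read here, and it shows that replacing (2-methoxy-1-(methoxymethyl)ethyl)amino with the all-carbon 2-ethylbutyl, which removes the nitrogen and both oxygens, leaves the half-life within the scatter. No measurement shown gives a reason for this flat result. Still open, on these data alone, is whether a quite different group at this position, such as a morpholine ring or a carboxylic acid, would move the half-life beyond the scatter.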